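Aryl substituent swap on the shared core, rat aorta

The source may hold more compounds than are shown below. What is called first, only, known or untested is meant among the compounds shown, and "the series" means these compounds.

Compound 1 `CC1(C)Oc2ccc(C#N)cc2[C@@H](/N=C(\NC#N)Nc2ccc(Cl)cc2)[C@@H]1O` gives 1800 nM in a functional assay (aorta) with Rattus norvegicus as the target; a lower number here means a stronger inhibitor, a higher number a weaker inhibitor. For compound 2 `CC1(C)Oc2ccc(C(=O)Nc3ccccc3)cc2[C@@H](/N=C(\NC#N)Nc2ccc(Cl)cc2)[C@@H]1O` this assay reports only a limit, > 100000 nM. The step of an at least 55-fold higher number from compound 1 to compound 2 (1.74 log units; beyond the scatter) is therefore large, and compound 2 stands at the weak end of what has been measured, on (the limit of > 100000 nM in this assay, at which 1 of the 2 values shown sits). Compound 3 `CC1(C)Oc2ccc(S(=O)(=O)NC3CCCCC3)cc2[C@@H](/N=C(\NC#N)Nc2ccc(Cl)cc2)[C@@H]1O` has not yet been measured in this assay; it differs from compound 2 by cyclohexylsulfamoyl in place of phenylcarbamoyl on an aromatic carbon. Within the data shown here, only one measured step bears on this change, an at least 55-fold higher number from compound 1 to compound 2 (1.74 log units; beyond the scatter), and it shows that the cyano compound sits far from the limit reached with phenylcarbamoyl. The group that enters is of about the same heavy-atom count as the one that leaves, as the difference shows, so a return toward the number of compound 1 is not expected; the step of an at least 1.6-fold lower number from compound 2 to compound 3 (0.22 log units; that floor lies within the scatter) is expected to stay within the scatter, and a limit may again be all that this assay reports. Compound 3 is estimated at 60000 nM, within a range from 5000 nM to 300000 nM.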

Compound 3, half-maximal inhibitory concentration: 11700 nM
The estimate for compound 3 lay 5.1-fold (0.71 log units) above the measured number, within the range that was stated.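

In this assay, the aromatic carbon that carries the variable group can hold a group of about the same heavy-atom count as phenylcarbamoyl and still give a measurable number, with an at least 8.5-fold lower number from compound 2 to compound 3 (0.93 log units; beyond the scatter), so heavy-atom count alone does not set the result at this position. Compound 1, with cyano, remains the strongest of the three, and a 6.5-fold higher number from compound 1 to compound 3 (0.81 log units; beyond the scatter) shows that cyclohexylsulfamoyl gives up only a modest step against the smaller group. Compound 2 is held only as a limit of the assay and not as a number: the limit of > 100000 nM in this assay, at which 1 of the 3 values shown sits.

The step from phenylcarbamoyl to cyclohexylsulfamoyl exchanges the linking group and the ring together, so the compounds shown cannot assign the gain to either one; cyclohexylcarbamoyl and phenylsulfamoyl would separate the two. From the compounds shown here alone, it also remains open whether a small group other than cyano, such as an amine or a carboxylic acid, would give a number near that of compound 1 at this position.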